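The compounds below may be only part of what the source reports. "The series", "measured", "known", "first", "only" and "open" are said of these compounds alone.

Compound 1 `CCC1(CCCCN2CCN(c3ccc(F)cc3)CC2)C(=O)Nc2ccccc21`: 10 mg/kg
Compound 2 `CCC1(CCCCN2CCC(C)CC2)C(=O)Nc2ccccc21`: "not determined" (no result reported)
Compound 3 `CCC1(CCCCN2CCN(c3ccc(F)cc3)CC2)C(=O)Nc2ccc(F)cc21`: > 20 mg/kg

Among the compounds with values here, in a functional assay on the whole organism (strain Wistar) with Rattus norvegicus as the target, with a stated time of 5 min (a higher number here means that more compound is needed for the effect, a lower number that less compound is needed), compound 1 gives 10 mg/kg, the only plain number among the three measured compounds. For compound 2 the result in this assay is "not determined" (no result reported). Compound 3 reached only a limit of the assay, > 20 mg/kg. Within the data shown here, the one measured step, an at least 2.0-fold higher number from compound 1 to compound 3 (0.30 log units; that floor lies within the scatter), rests on that limit of > 20 mg/kg in this assay, at which 1 of the 3 values shown sits, and concerns a different change from the one at hand. Compound 4 `CCC1(CCCCN2CCN(c3cccc(Cl)c3)CC2)C(=O)Nc2ccccc21` differs from compound 1 as follows: 3-chlorophenyl in place of 4-fluorophenyl on an amine nitrogen in a ring. Among the measured compounds shown here, no measured step bears on this exchange of one halogenated phenyl for another, so no movement beyond the scatter is expected. Compound 4 is therefore estimated at 10 mg/kg, with a range from 4 mg/kg to 25 mg/kg. The expected step of no change at the digits printed from compound 1 to compound 4 (within the scatter) lies within the scatter.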

Compound 4, minimum effective dose: > 20 mg/kg
Compound 4 was reported as a limit; the forecaster's own chance of this, stated with the estimate: 30%; middle value at least 2.0-fold (0.30 log units) away from the limit.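

In this assay, putting 3-chlorophenyl in place of 4-fluorophenyl on the amine nitrogen gives an at least 2.0-fold higher number from compound 1 to compound 4 (0.30 log units; that floor lies within the scatter). Within the data shown here, this is the first reading for a change at this position, as the earlier step concerned a fluoro on the shared core, but it does not establish a real loss. Compound 4 reads only as a limit of the assay, leaving the true size of the step unknown: the limit of > 20 mg/kg in this assay, at which 2 of the 4 values shown sit.

From the compounds shown here alone, whether any shift follows the chlorine or its place on the phenyl ring stays open. Answering that would take a compound such as the 4-chlorophenyl or 3-fluorophenyl analogue.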